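A few compounds are considered here, and "the series" means these few. Any claim that something is new, unique, unknown or untested is made for them only; others in the source may bear on it.

In a functional assay on MIA PaCa-2 cells (Homo sapiens) for cytotoxicity, read by resazurin assay, with a stated time of 72 h (a higher number here means a weaker inhibitor, a lower number a stronger inhibitor), compound 1 (`COc1cc(OC)c(C(=O)/C=C/c2ccccc2)c(OC)c1`) gives > 20000 nM, which is a limit and not a number. For the measured compounds named here, compound 2 (`C=CCOc1ccccc1Cc1c(OC)cc(OC)c(C(=O)/C=C/c2ccccc2)c1OC`) gives 9400 nM, the only actual number so far. Going by the values given here, the one measured step is an at least 2.1-fold lower number from compound 1 to compound 2 (0.32 log units; beyond the scatter), with 2-(allyloxy)benzyl in place of hydrogen on an aromatic carbon. Compound 3 (`COc1cc(OC)c(C(=O)/C=C/c2ccccc2)c(OC)c1Cc1ccccc1O`) keeps the benzyl link but carries hydrogen in place of allyl on an oxygen on an aromatic ring, so that 2-(allyloxy)benzyl becomes 2-hydroxybenzyl: hydrogen in place of allyl on an oxygen on an aromatic ring. The measured step introduced the whole group, so it bears only indirectly and does not isolate the allyl. No step beyond the scatter is therefore expected in this assay, and no direction is favoured. The expected change is a 1.2-fold lower number from compound 2 to compound 3 (0.07 log units; within the scatter). For compound 3 the estimated value is 8000 nM, with an expected range of 3000 nM to 20000 nM.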

Compound 3, half-maximal inhibitory concentration: 4100 nM
Compound 3: middle estimate off by 2.0-fold (0.29 log units), on the high side, within the range that was stated.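

In this assay, for the compounds shown here, allyloxy to hydroxy gives a 2.3-fold lower number from compound 2 to compound 3 (0.36 log units; beyond the scatter), so the allyl is not required for activity at this oxygen, and its replacement by hydrogen goes with a gain that the earlier compounds could not show. Measured against the unsubstituted core, 2-hydroxybenzyl in place of hydrogen on an aromatic carbon gives an at least 4.8-fold lower number from compound 1 to compound 3 (0.68 log units; beyond the scatter), so the smaller substituent still carries a gain beyond the scatter. This step is only a bound, and its true size stays unknown, as compound 1 stands at a limit and not a number: the limit of > 20000 nM in this assay, at which 1 of the 3 values shown sits.

On these data alone, whether the gain belongs to the free hydroxy itself or only to the loss of allyl stays open. A methoxy group or an amine in place of the hydroxy on the benzyl ring would separate the two readings.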